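A Methoxy Group Added to Compound 2

This account rests on a few compounds, and the source may have more. Where it says the series, first, only, none or still open, it means among the compounds named here.

Compound 1 `CC(=O)C[C@H]1O[C@@H](On2cc(CN3C(=O)/C(=N\Nc4ccccc4)c4ccccc43)nn2)[C@H](OC(C)=O)[C@@H](OC(C)=O)[C@@H]1OC(C)=O` and compound 2 `CC1(C)O[C@H]2O[C@H](Cn3cc(CN4C(=O)/C(=N\Nc5ccccc5)c5ccccc54)nn3)[C@H](O)[C@H]2O1` were both tested in an ADME assay on Vero cells (Chlorocebus sabaeus) for cytotoxicity, read by fluorescence and resazurin assay, with a stated time of 3 days; a lower number here means that less compound is tolerated, a higher number that more compound is tolerated. In this assay compound 1 gives 108000 nM, and compound 2 gives 82100 nM. The two numbers sit within the usual scatter of each other, so compound 2 stands level with compound 1 rather than apart from it. Compound 3 `COc1ccc(N/N=C2\C(=O)N(Cc3cn(C[C@H]4O[C@@H]5OC(C)(C)O[C@@H]5[C@H]4O)nn3)c3ccccc32)cc1` differs from compound 2 by methoxy in place of hydrogen on an aromatic carbon. For the measured compounds named here, no comparable step between measured compounds is available. The change from compound 2 to compound 3 is expected to give a 1.0-fold lower number from compound 2 to compound 3 (0.01 log units; within the scatter), nothing beyond the scatter. Compound 3 is therefore estimated at 80000 nM, within 40000 nM to 160000 nM.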

Compound 3, half-maximal cytotoxic concentration: 74500 nM
Beside the measured number, compound 3's estimate is 1.1-fold (0.03 log units) above it, and the stated range covers the measured number.
By their numbers in this assay, from the lowest: compounds 3, 2 and 1 (each within the scatter of the next).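

In this assay, for the compounds shown here, methoxy in place of hydrogen, on an aromatic carbon para to a large group, gives a 1.1-fold lower number from compound 2 to compound 3 (0.04 log units; within the scatter) and so provides the first single-place comparison in this set. It shows that going from phenyl to 4-methoxyphenyl leaves the number within the scatter at this position. No measurement shown offers an explanation for this result.

The compounds shown leave open whether an amine or a carboxylic acid on this same aromatic carbon would also stay within the scatter. They also leave open whether a longer chain in place of methoxy would do so.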